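The compounds below may be only part of what the source reports. "The series", "measured", "known", "first", "only" and "open" are said of these compounds alone.

Compound 1 `CC(=O)CCCCC(=O)N1CCN(c2nccc(Oc3cccc(C)c3)n2)CC1`: in an assay on isolated protein for inhibition of tyrosine-protein kinase Fes/Fps (Homo sapiens), read by HTRF, tested at 10 uM (a higher number here means more inhibition at the concentration tested (going by the name of the read-out), a lower number less inhibition), compound 1 gives 16%.
Compound 2 `Cc1cccc(N(C)c2cc(Nc3cccc(C(=O)N4CCCC5CCCCC54)c3)ncn2)c1`: compound 2 gives 7%.
Compound 3 `COC[C@@H]1CCCN1C(=O)[C@@H]1CCCN1c1nccc(Nc2ccccc2)n1`: compound 3 gives 8%.

Compound 2 shows the lowest of the three numbers, yet its gap to compound 3 and its gap to compound 1 both fall within the usual scatter, so no order among the three can be read from them. Compound 4 `Cc1cccc(N(C)c2cc(Nc3cccc(C(=O)N(CC(C)C)CC(C)C)c3)ncn2)c1` has not been measured. It differs from compound 2 in one place: a group of 9 heavy atoms (8 carbon, 1 nitrogen; no ring) in place of a group of 10 heavy atoms (9 carbon, 1 nitrogen; one six-membered non-aromatic ring of carbon only, one six-membered non-aromatic ring with 1 hetero atom), on a carbonyl carbon. Among the compounds with values here, no pair of measured compounds isolates a change of this kind, so nothing here points to a shift in either direction. The step is expected to stay within the scatter, a number 1 percentage points higher from compound 2 to compound 4 (within the scatter). Compound 4 is therefore estimated at 8%, with a range from 0% to 20%.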

Compound 4, a percentage reported as inhibition, at one concentration (the size of the read-out at that concentration, not a potency): 7%
For compound 4 the middle estimate is 1 percentage points above the measured one; the range from low to high includes it.
By their numbers in this assay, from the lowest: compounds 2, 4, 3 and 1 (each within the scatter of the next).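

In this assay, putting diisobutylamino on the carbonyl carbon in place of the group with two six-membered non-aromatic rings gives no change at the digits printed from compound 2 to compound 4 (within the scatter) and so shows that, for this pair, those rings can give way to an open-chain group without a readable shift. Nothing available gives a reason for this result. Going by these compounds, whether a morpholine or a piperazine on this carbonyl carbon would move the number beyond the scatter stays open, and so does whether any change elsewhere on the shared core would.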